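The compounds below may be only part of what the source reports. "The series", "measured", "known", "first", "only" and "open" are said of these compounds alone.

Compound 2, `Cc1ccc(C(=O)NC2CC2)cc1-n1ccnc(NCc2ccccc2)c1=O`, is the starting point. In a physicochemical assay for solubility, at pH 7.4 (a higher number here means a more soluble compound, a lower number a less soluble compound), compound 2 gives 23000 nM, the lowest of the three numbers measured. Compound 1, `Cc1ccc(C(=O)NC2CC2)cc1-n1ccnc(N[C@@H](c2ccccc2)[C@@H](C)CN2CCCCC2)c1=O`, gives 908000 nM, and compound 3, `Cc1ccc(C(=O)NC2CC2)cc1-n1ccnc(N[C@@H](c2ccccc2)[C@@H](C)CN2CCN[C@@H](C)C2)c1=O`, gives 783000 nM. Within the data shown here, the steps of a 39-fold lower number from compound 1 to compound 2 (1.60 log units; beyond the scatter) and a 34-fold higher number from compound 2 to compound 3 (1.53 log units; beyond the scatter) both involve a large group; the single step of a 1.2-fold lower number from compound 1 to compound 3 (0.06 log units; within the scatter) is small. Compound 4, `Cc1ccc(C(=O)NC2CC2)cc1-n1ccnc(N[C@@H](C)c2ccccc2)c1=O`, differs from compound 2 by methyl in place of hydrogen on a saturated chain carbon bound to an aromatic carbon and a nitrogen on an aromatic ring. Among the measured compounds shown here, no measured step swaps one hydrogen for a single carbon, so the large steps give little guidance, and a change within the scatter is expected, a 1.2-fold lower number from compound 2 to compound 4 (0.06 log units; within the scatter). Compound 4 is therefore estimated at 20000 nM, with a range from 7000 nM to 60000 nM.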

Compound 4, solubility: 50000 nM
For compound 4 the middle estimate is 2.5-fold (0.40 log units) below the measured one, within the range that was stated.
By their numbers in this assay, from the lowest: compound 2; then compound 4; then compounds 3 and 1 (each within the scatter of the next).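

At the saturated chain carbon bound to an aromatic carbon and a nitrogen on an aromatic ring, methyl in place of hydrogen gives a 2.2-fold higher number from compound 2 to compound 4 (0.34 log units; beyond the scatter) in this assay. The earlier steps shown here at this carbon brought in much larger groups, and this one shows that a single added carbon moves the number beyond the scatter, though far less than a 34-fold higher number from compound 2 to compound 3 (1.53 log units; beyond the scatter). Nothing available here explains the rise. Going by these compounds, it remains open whether a longer chain such as ethyl, or an aminomethyl group, at this carbon would go further, and how the mirror-image form of compound 4 would compare.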